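Working notes: compound 4 against the measured set

A few compounds are considered here, and "the series" means these few. Any claim that something is new, unique, unknown or untested is made for them only; others in the source may bear on it.

Compound 1 `COc1cccc(Cc2cnc(CCc3ccc(-c4ccccc4C(=O)O)cc3)[nH]2)c1` gives 79 nM in an in vitro functional assay on cells for agonist activity at Bombesin receptor subtype-3 (Mus musculus), read by luminescence and calcium flux; on this read-out higher numbers stand for an effect only at larger amounts of compound and lower numbers for an effect already at smaller amounts. Compound 2 `O=C(O)c1ccccc1-c1ccc(CCc2ncc(CC3CC3)[nH]2)cc1` gives 72 nM; the step of a 1.1-fold lower number from compound 1 to compound 2 (0.04 log units; within the scatter) is within the scatter. Compound 3 `CC(C)(C)c1cnc(CCc2ccc(-c3ccccc3C(=O)O)cc2)[nH]1` gives 2750 nM, the highest number of the three, with a 35-fold higher number from compound 1 to compound 3 (1.54 log units; beyond the scatter) and a 38-fold higher number from compound 2 to compound 3 (1.58 log units; beyond the scatter) both large and beyond the scatter. Compound 4 `O=C(O)c1ccccc1-c1ccc(CCc2ncc(Cc3cccc(Cl)c3)[nH]2)cc1` is not yet measured and differs from compound 3 by 3-chlorobenzyl in place of tert-butyl on an aromatic carbon. This runs opposite to the steps that led to compound 3, where 3-methoxybenzyl or cyclopropylmethyl rather than tert-butyl on an aromatic carbon went with far lower numbers. A large downward step is therefore expected, a 31-fold lower number from compound 3 to compound 4 (1.49 log units; beyond the scatter). Compound 4 is expected to give 90 nM, within 35 nM to 250 nM.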

Compound 4, half-maximal effective concentration: 31 nM
Beside the measured number, compound 4's estimate is 2.9-fold (0.46 log units) above it; measured number below the stated range.
By their numbers in this assay, from the lowest: compound 4; then compounds 2 and 1 (each within the scatter of the next); then compound 3.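

On the aromatic carbon of the five-membered aromatic ring, 3-chlorobenzyl separates sharply from tert-butyl (an 89-fold lower number from compound 3 to compound 4 (1.95 log units; beyond the scatter)). Unlike the step between compound 1 and compound 2, which stayed within the scatter, changes among the lower-number groups now register: chloro in place of methoxy gives a modest step (a 2.5-fold lower number from compound 1 to compound 4 (0.41 log units; beyond the scatter)), and 3-chlorobenzyl in place of cyclopropylmethyl gives another (a 2.3-fold lower number from compound 2 to compound 4 (0.37 log units; beyond the scatter)). No measurement here gives a reason for these steps.

Open, going by these compounds, is how a benzyl ring carrying an amine or a nitrile in place of chloro would stand. Also open, on these data alone, is whether a longer chain bearing that ring would keep the low number.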